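A few compounds are considered here, and "the series" means these few. Any claim that something is new, unique, unknown or untested is made for them only; others in the source may bear on it.

Measured so far:
Compound 1 `Cc1ccc(C)c(NC(=O)CSc2nnc(-c3ccoc3C)n2Cc2ccco2)c1` in a functional assay on CHO cells for antagonist activity at Orexin/Hypocretin receptor type 1 (Homo sapiens), read by FLIPR and calcium flux (on this read-out lower numbers stand for stronger inhibition and higher numbers for weaker inhibition), gives only a limit of the assay, > 15800 nM.
Compound 2 `Cc1cccc(NC(=O)CSc2nnc(-c3ccoc3C)n2Cc2ccco2)c1C` in this assay gives only a limit, > 15800 nM.
Compound 3 `Cc1ccc(NC(=O)CSc2nnc(-c3ccoc3C)n2Cc2ccco2)cc1` in this assay gives only a limit, > 15800 nM.

Compound 3 therefore stands nowhere above the floor of the series: every value shown sits at the same limit, (the limit of > 15800 nM in this assay, at which 3 of the 3 values shown sit). Within the data shown here, because of the limit of > 15800 nM in this assay, at which 3 of the 3 values shown sit, the three steps among the measured compounds, a step that the two limits leave unreadable from compound 1 to compound 2, a step that the two limits leave unreadable from compound 1 to compound 3 and a step that the two limits leave unreadable from compound 2 to compound 3, cannot be sized; they tell only that moving methyl groups around the phenyl on the amide-type nitrogen left nothing measurable.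

Compound 4 `Cc1occc1-c1nnc(SCC(=O)Nc2ccc(F)cc2)n1Cc1ccco1` is the next variation on the same ring: fluoro in place of methyl on an aromatic carbon. Among the measured compounds shown here, all three measured steps bear on this position of the molecule, but none has a readable size, so they give no direction to expect, only that no step beyond the scatter has yet appeared anywhere.

The expectation for compound 4 is accordingly a further limit rather than a number, with a step that the limit leaves unreadable from compound 3 to compound 4 the step implied. Compound 4 is estimated at 25000 nM, in the range 8000 nM to 80000 nM.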

Compound 4, inhibition constant: > 15800 nM
Compound 4: no number, only a limit; the forecaster's own chance of this, stated with the estimate: 85%; the middle value does not contradict the limit.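

No new step can be read from compound 4 against compound 1, compound 2 or compound 3, since each pair rests on two limits: the limit of > 15800 nM in this assay, at which 4 of the 4 values shown sit.

The compounds shown leave open which change to the shared core, if any, would give a readable number in this assay.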